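Microsomal clearance notes: compound 4 against compounds 1 to 3

The compounds below may be only part of what the source reports. "The series", "measured", "known", "first", "only" and "open" are said of these compounds alone.

Measured so far:
compound 1 `CC[C@H](C)[C@@H]1C(=O)N[C@H](C2Cc3ccccc3C2)C(=O)N1[C@@H](C(=O)N(C)C)c1ccc(C)[n+]([O-])c1` — 1 mL.min-1.g-1
compound 2 `CC[C@H](C)[C@@H]1C(=O)N[C@H](C2Cc3ccccc3C2)C(=O)N1[C@@H](C(=O)N1CCOCC1)c1ccc(C)nc1` — 3 mL.min-1.g-1
compound 3 `CC[C@H](C)[C@@H]1C(=O)N[C@H](C2Cc3ccccc3C2)C(=O)N1[C@@H](C(=O)NC)c1cc(C)cnc1C` — 3 mL.min-1.g-1

In an in vitro ADME assay on microsomes from liver (Homo sapiens) for metabolic stability (a lower number here means slower removal, a higher number faster removal of the compound), compound 1 gives 1 mL.min-1.g-1, the lowest of the three numbers. Compound 2 gives 3 mL.min-1.g-1 and compound 3 gives 3 mL.min-1.g-1; each of these stands beyond the scatter from compound 1, and the two of them lie within the scatter of each other. Within the data shown here, no two of the measured compounds differ in only one place, so no single step between measured values can be read off.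

Compound 4 `CC[C@H](C)[C@@H]1C(=O)N[C@H](C2Cc3ccccc3C2)C(=O)N1[C@@H](C(=O)N(C)C)c1cnc(C)cc1C` has not yet been measured in this assay. It differs from compound 1 in one place: a group of 8 heavy atoms (7 carbon, 1 nitrogen; one six-membered aromatic ring with 1 hetero atom) in place of a group of 8 heavy atoms (6 carbon, 1 nitrogen, 1 oxygen; one six-membered aromatic ring with 1 hetero atom), on a saturated chain carbon bound to an amide-type nitrogen in a ring and a carbonyl carbon. The group that leaves carries an oxygen; the group that enters does not, and the aromatic rings of compounds 2 and 3 likewise carry no oxygen. Both of those compounds sit higher than compound 1 in this assay.

On that basis the step is expected to go upward and beyond the scatter, by about a 3.0-fold higher number from compound 1 to compound 4 (0.48 log units; beyond the scatter). For compound 4 the value in this assay is estimated at 3 mL.min-1.g-1, within a range of 1.5 mL.min-1.g-1 to 6 mL.min-1.g-1. Compounds 2 and 3 are the only anchors for this expectation.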

Compound 4, intrinsic clearance in microsomes: 9 mL.min-1.g-1
Estimate against measurement, compound 4: 3.0-fold (0.48 log units) below; the measured number lies above the stated range.
By their numbers in this assay, from the lowest: compound 1; then compounds 2 and 3 (each within the scatter of the next); then compound 4.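

In this assay, among these compounds, the entry of 4,6-dimethylpyridin-3-yl on the saturated chain carbon bound to an amide-type nitrogen in a ring and a carbonyl carbon gives a 9.0-fold higher number from compound 1 to compound 4 (0.95 log units; beyond the scatter) as the first step that can be read at a single place, so a change at this place alone moves the read-out beyond the scatter. The leaving and entering groups have the same counts of heavy atoms, hydrogen-bond donors and hydrogen-bond acceptors, and neither carries a net charge, so the step arises with these counts unchanged while an oxygen leaves and a carbon enters. Nothing measured here bears on the origin of this step.

Among the compounds shown here, with only this one step, the oxygen and the carbon cannot be told apart as the source of the change, and whether the same step would hold on another part of the core stays unknown. From the compounds shown here alone, how a hydroxymethyl group, a fluorine or an amine on the aromatic ring at this place would read remains open.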